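This account rests on a few compounds, and the source may have more. Where it says the series, first, only, none or still open, it means among the compounds named here.

In a functional assay on SW480 cells (Homo sapiens) for antiproliferative activity, read by MTT assay, with a stated time of 48 h (a higher number here means a weaker inhibitor, a lower number a stronger inhibitor), compound 1 `CCCCCCCC(CCO)n1cnc2c(N)ncnc21` gives > 50000 nM, which is a limit of the assay. Compound 2 `CCCCCCCCC(CCO)n1cnc2c(N)ncnc21` gives 20700 nM. Within the data shown here, the one measured step is an at least 2.4-fold lower number from compound 1 to compound 2 (0.38 log units; beyond the scatter), and it rests on that limit. Among the measured compounds shown here, compound 3 `CCCCCCCCCCC(CCO)n1cnc2c(OC)ncnc21` gives 8260 nM, the lowest number so far, with compound 2 higher. Compound 4 `CCCCCCCCCCC(CCO)n1cnc2c(N)ncnc21` keeps the chain of compound 3 and changes as amino in place of methoxy on an aromatic carbon. For the measured compounds named here, no measured step covers this exchange. The chain step an at least 2.4-fold lower number from compound 1 to compound 2 (0.38 log units; beyond the scatter) points to compound 4 falling under compound 2, so no change beyond the scatter is expected from compound 3. The expected step is a 1.2-fold lower number from compound 3 to compound 4 (0.07 log units; within the scatter). Compound 4 is estimated at 7000 nM, with an expected range of 2500 nM to 20000 nM.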

Compound 4, half-maximal inhibitory concentration: 1200 nM
Estimate against measurement, compound 4: 5.8-fold (0.77 log units) above, and the stated range ends above it.
By their numbers in this assay, from the lowest: compound 4; then compound 3; then compound 2. At a limit, above all of these: compound 1.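

Among these compounds, at this aromatic carbon, amino in place of methoxy is the first exchange on the shared core that can be read, and in this assay it lowers the number (a 6.9-fold lower number from compound 3 to compound 4 (0.84 log units; beyond the scatter)). With amino held, ethyl in place of hydrogen on the chain also lowers it (a 17-fold lower number from compound 2 to compound 4 (1.24 log units; beyond the scatter)), so the chain step seen earlier carries on past compound 2. Compound 1 stands at a limit, and the step to compound 4 (an at least 41-fold lower number from compound 1 to compound 4 (1.61 log units; beyond the scatter)) rests on it: the limit of > 50000 nM in this assay, at which 1 of the 4 values shown sits. Open, from the compounds shown here alone, is whether a longer chain lowers the number further. Also open, going by these compounds, is whether methylamino at this carbon keeps what amino gains over methoxy.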